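Changing the Amine at the End of a Side Chain

The source may report more compounds than this note shows. Statements on the series, on what has been measured and on what is new or still open speak of the compounds shown alone.

In a functional assay on PC-3 cells (Homo sapiens) for antiproliferative activity, read by MTT assay, with a stated time of 72 h (on this read-out lower numbers stand for stronger inhibition and higher numbers for weaker inhibition), compound 1 `O=C(N/N=C/c1ccc(O)cc1)Nc1ccc(Oc2ccnc3[nH]ccc23)c(F)c1` gives 2780 nM and compound 2 `O=C(N/N=C/c1ccc(O)cc1O)Nc1ccc(Oc2ccnc3[nH]ccc23)c(F)c1` gives 13000 nM. Compound 3 `CN(C)CCn1cccc1/C=N/NC(=O)Nc1ccc(Oc2ccnc3[nH]ccc23)c(F)c1` gives 1600 nM and sits level with compound 1 (a 1.7-fold lower number from compound 1 to compound 3 (0.24 log units; within the scatter)) but apart from compound 2 (an 8.1-fold lower number from compound 2 to compound 3 (0.91 log units; beyond the scatter)). Compound 4 `O=C(N/N=C/c1cccn1CCCN1CCCCC1)Nc1ccc(Oc2ccnc3[nH]ccc23)c(F)c1` differs from compound 3 in one place ((piperidin-1-yl)methyl in place of dimethylamino on a saturated chain carbon, two bonds along the chain from an aromatic nitrogen): 2-(dimethylamino)ethyl becomes 3-(piperidin-1-yl)propyl. Going by the values given here, no measured step touches this chain, since those reaching compound 3 replace the whole aromatic group. Yet a 4.7-fold higher number from compound 1 to compound 2 (0.67 log units; beyond the scatter) shows that one added hydroxy can move the number, so the range stays wide. The estimated change is a 1.1-fold higher number from compound 3 to compound 4 (0.05 log units; within the scatter) and no step beyond the scatter is expected. Compound 4 is estimated at 1800 nM with an expected range from 600 nM to 5000 nM in this test.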

Compound 4, half-maximal inhibitory concentration: 2840 nM
Compound 4: the middle estimate sits 1.6-fold (0.20 log units) below what was measured; measured number inside the range.
By their numbers in this assay, from the lowest: compounds 3, 1 and 4 (each within the scatter of the next); then compound 2.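

Going by these compounds alone, this is the first measured step that touches the chain itself, since the earlier steps replaced the whole aromatic group. In this assay, going from 2-(dimethylamino)ethyl to 3-(piperidin-1-yl)propyl gives a 1.8-fold higher number from compound 3 to compound 4 (0.25 log units; within the scatter), so a larger group with a six-membered ring leaves the number within the usual scatter. No available evidence bears on this result.

Chain length and the amine change together here, so their separate contributions stay unknown. A 3-(dimethylamino)propyl chain or a 2-(piperidin-1-yl)ethyl chain would separate them, and a morpholine or carboxylic acid at the chain end remains an open question.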